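Adding a Hydroxy Group to Compound 1

A few compounds are considered here, and "the series" means these few. Any claim that something is new, unique, unknown or untested is made for them only; others in the source may bear on it.

Measured compounds:
Compound 1, `O=C(O)Cc1sc(C(c2ccccc2)c2ccccc2)nc1-c1ccc(F)cc1`, gives 80% in an in vitro functional assay on HEK285-7 cells for antagonist activity at prostaglandin D2 receptor 2 (Homo sapiens), read by BRET and beta-arrestin recruitment; a higher number here means a larger maximal response, a lower number a smaller maximal response.
Compound 2, `O=C(O)Cc1sc(C(c2ccccc2)c2ccccc2)nc1-c1ccccc1`, gives 80% in this assay.

On the numbers available, compound 1 stands level with compound 2: the step of no change at the digits printed from compound 1 to compound 2 (within the scatter) lies within the usual scatter of the assay. Among the measured compounds shown here, that single measured step, swapping a fluoro for a hydrogen on one of the outer rings, is the only comparison in the set.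

The next compound, compound 3, `O=C(O)Cc1sc(C(c2ccccc2)c2ccc(O)cc2)nc1-c1ccc(F)cc1`, differs from compound 1 in one place: hydroxy in place of hydrogen on an aromatic carbon. The measured step from compound 1 to compound 2 concerns a different ring and a different kind of group, so it bears only loosely on this change; it does show that a small change at the edge of the molecule left the maximal response untouched. For the measured compounds named here, no measured step speaks to a hydroxy group itself.

On that basis the step of a number 2 percentage points lower from compound 1 to compound 3 (within the scatter) is expected to stay within the scatter. Compound 3 is therefore estimated to give 78% in this assay, with a range from 60% to 95%.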

Compound 3, largest response reached (reported as efficacy), in percent of the reference or control that the assay uses: 80%
Estimate against measurement, compound 3: 2 percentage points below; the range from low to high includes it.
By their numbers in this assay, from the lowest: compounds 1, 2 and 3 (each within the scatter of the next).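

In this assay the change from phenyl to 4-hydroxyphenyl gives no change at the digits printed from compound 1 to compound 3 (within the scatter), so a hydroxy group is accepted at this position, para to a large group, with no visible effect on the maximal response. Among the compounds shown here, the earlier pair of compounds showed only that fluoro and hydrogen could be exchanged on the other outer ring, so this is the first reading on a change at this ring and the first on a group that brings a hydrogen-bond donor and acceptor. Nothing available accounts for the unchanged read-out.

The compounds shown leave open whether this position would accept other groups in the same way, such as a methoxy group, an amine or a carboxylic acid, and whether hydroxy would be accepted on the ring that carries the fluoro in compound 1. They also leave open whether a hydroxy group at this position alters anything other than the maximal response, since that is the only read-out shown here.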